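Moving a fluorine on the amide ring of a quinoline series

The compounds below may be only part of what the source reports. "The series", "measured", "known", "first", "only" and "open" are said of these compounds alone.

Measured compounds:
- compound 1 `CCN1CCN(c2cc(C)c3cc(NC(=O)c4ccc(F)cc4)ccc3n2)CC1`: 4030 nM
- compound 2 `CCN1CCN(c2cc(C)c3cc(NC(=O)c4ccccc4Br)ccc3n2)CC1`: 27500 nM
- compound 3 `Cc1cc(NCCN2CCCC2)nc2ccc(NC(=O)c3ccc(Cl)c(Cl)c3)cc12`: 1280 nM

In a functional assay on MCF7 cells (Homo sapiens) for antiproliferative activity, read by MTT assay, with a stated time of 72 h (on this read-out higher numbers stand for weaker inhibition and lower numbers for stronger inhibition), compound 1 gives 4030 nM, the second highest of the three numbers: compound 3 shows a lower number and compound 2 a higher one. Compound 4 `CCN1CCN(c2cc(C)c3cc(NC(=O)c4cccc(F)c4)ccc3n2)CC1` has not been measured. It differs from compound 1 by 3-fluorophenyl in place of 4-fluorophenyl on a carbonyl carbon, so the same atoms are present and only the place of the fluorine on the amide-linked ring has moved.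

For the measured compounds named here, one measured step bears on this: a 6.8-fold higher number from compound 1 to compound 2 (0.83 log units; beyond the scatter). That step, however, both moved the substituent and exchanged fluorine for bromine, so it speaks only loosely to a pure shift of fluorine. Compound 3 shows a lower number than compound 1 but differs at several places, so no single step can be read from it.

A shift of one fluorine around the ring is therefore expected to give a small change, probably toward a somewhat higher number, a 1.4-fold higher number from compound 1 to compound 4 (0.14 log units; within the scatter). Compound 4 is estimated at 5500 nM, within 2000 nM to 16000 nM.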

Compound 4, half-maximal inhibitory concentration: 8920 nM
For compound 4 the middle estimate is 1.6-fold (0.21 log units) below the measured one, within the range that was stated.
By their numbers in this assay, from the lowest: compound 3; then compound 1; then compound 4; then compound 2.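

In this assay, moving the fluorine alone has a modest effect that lies beyond the usual scatter, with a 2.2-fold higher number from compound 1 to compound 4 (0.35 log units; beyond the scatter) as 3-fluorophenyl replaces 4-fluorophenyl on the carbonyl carbon. The atoms stay the same, so for this pair the place of the fluorine on the ring changes the result by itself, which the earlier step from compound 1 to compound 2 could not show, as it also exchanged the halogen. The other new step, a 3.1-fold lower number from compound 2 to compound 4 (0.49 log units; beyond the scatter), again changes both the halogen and its place, so it cannot separate the two, and no measurement here explains either step.

From the compounds shown here alone, it remains open whether the same shift of fluorine would have a similar effect with the side chain of compound 3. A methoxy group or a carboxylic acid in place of the fluorine also remains untested among the compounds shown.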